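One Substituent Swap on the Oxygen of the Shared Core

The source may hold more compounds than are shown below. What is called first, only, known or untested is meant among the compounds shown, and "the series" means these compounds.

Compound 2 `Nc1ccc2cccc(OCCC(F)(F)F)c2n1` gives 722 nM in an assay on cells with melanin-concentrating hormone receptor 1 (Homo sapiens) as the target, read by radioligand binding; a lower number here means a stronger inhibitor, a higher number a weaker inhibitor. Among the measured compounds shown here, it shows the highest of the two numbers measured so far; its nearest neighbour is compound 1 `COCC(C)Oc1cccc2ccc(N)nc12`, which in this assay gives 606 nM, and the step of a 1.2-fold higher number from compound 1 to compound 2 (0.08 log units; within the scatter) lies within the scatter. Compound 3 `Nc1ccc2cccc(OC3CCCC3)c2n1` has not yet been measured; it differs from compound 2 by cyclopentyl in place of 3,3,3-trifluoropropyl on an oxygen on an aromatic ring. For the measured compounds named here, the only measured step that bears on this change is the exchange at the same oxygen on the aromatic ring, a 1.2-fold higher number from compound 1 to compound 2 (0.08 log units; within the scatter), where one group was replaced by another with no effect beyond the scatter. On that basis the expected step of a 1.2-fold lower number from compound 2 to compound 3 (0.08 log units; within the scatter) is small, with no direction beyond the scatter. Compound 3 is therefore estimated at 600 nM in this assay, with a range from 200 nM to 1800 nM.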

Compound 3, half-maximal inhibitory concentration: > 2000 nM
Compound 3 was reported as a limit (the forecaster's own chance of this, stated with the estimate: 3%); at least 3.3-fold (0.52 log units) between middle value and limit.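

In this assay the value of compound 3 is a limit and not a number: the limit of > 2000 nM in this assay, at which 1 of the 3 values shown sits. It shows that the group on this oxygen can matter: cyclopentyl in place of 3,3,3-trifluoropropyl gives an at least 2.7-fold higher number from compound 2 to compound 3 (0.44 log units; beyond the scatter), and cyclopentyl in place of 1-(methoxymethyl)ethyl gives an at least 3.3-fold higher number from compound 1 to compound 3 (0.51 log units; beyond the scatter). Among the compounds shown here, the earlier exchange at this oxygen, between the groups of compound 1 and compound 2, stayed within the scatter, so this is the first change here to go beyond it.

Still open, going by these compounds, is whether the ring itself matters, a question that a butyl chain of carbon only, or a cyclopropyl or phenyl ring on the same oxygen, could address. Also open, on these data alone, is how an amine or a carboxylic acid at the end of a longer chain on this oxygen would fare.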